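The source may report more compounds than this note shows. Statements on the series, on what has been measured and on what is new or still open speak of the compounds shown alone.

Four compounds from one series were compared in a functional assay on HepG2 cells (Homo sapiens) for antiproliferative activity, read by CCK-8 assay, with a stated time of 72 h, tested at 2 uM; on this read-out higher numbers stand for a stronger effect at the one concentration tested and lower numbers for a weaker effect. Compound 1 `CC1CCN(c2nc(Cl)nc3c2ncn3Cc2ccc(/C=C/C(=O)Nc3ccccc3N)cc2)CC1` gives 8.73% in this assay. Compound 2 `Nc1ccccc1NC(=O)/C=C/c1ccc(Cn2cnc3c(Nc4cccc(Cl)c4)nc(Cl)nc32)cc1` gives 35.8% in this assay. The two differ by one change, ((3-chlorophenyl)amino in place of 4-methylpiperidin-1-yl on an aromatic carbon), and in this assay this change made a number 27.1 percentage points higher from compound 1 to compound 2 (beyond the scatter). Compound 3 `CC1CCN(c2nc(Cl)nc3c2ncn3Cc2ccc(C(=O)Nc3ccccc3N)cc2)CC1` gives 1.22% in this assay. It shares its core with compound 1 except for ((2-aminophenyl)carbamoyl in place of 2-((2-aminophenyl)carbamoyl)ethenyl on an aromatic carbon), a change that in this assay made a number 7.5 percentage points lower from compound 1 to compound 3 (within the scatter). Compound 4 `Nc1ccccc1NC(=O)c1ccc(Cn2cnc3c(Nc4cccc(Cl)c4)nc(Cl)nc32)cc1` has not yet been measured. Going by the values given here, it differs from compound 3 by (3-chlorophenyl)amino in place of 4-methylpiperidin-1-yl on an aromatic carbon, which is the same change, at the same place, as the one between compound 1 and compound 2. The expected step in this assay from compound 3 to compound 4 is a number 25.8 percentage points higher from compound 3 to compound 4 (beyond the scatter), resting on the step of a number 27.1 percentage points higher from compound 1 to compound 2 (beyond the scatter) and on the starting point of compound 3 at 1.22%. Compound 4 is therefore estimated to give about 27% in this assay, most likely between 12% and 42%.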

Compound 4, a percentage reported as inhibition, at one concentration (the size of the read-out at that concentration, not a potency): 29.9%
Beside the measured number, compound 4's estimate is 2.9 percentage points below it; measured number inside the range.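

In this assay, putting (3-chlorophenyl)amino in place of 4-methylpiperidin-1-yl gave a number 28.7 percentage points higher from compound 3 to compound 4 (beyond the scatter) and this change carried over from one core to the other with no real difference in size: the same change on two cores in this assay, a number 27.1 percentage points higher (beyond the scatter) from compound 1 to compound 2 and a number 28.7 percentage points higher (beyond the scatter) from compound 3 to compound 4, 1.6 percentage points apart, within the scatter of two such steps. Putting (2-aminophenyl)carbamoyl in place of 2-((2-aminophenyl)carbamoyl)ethenyl gave a number 5.9 percentage points lower from compound 2 to compound 4 (within the scatter) and this change also behaved alike on both cores: the same change on two cores in this assay, a number 7.5 percentage points lower (within the scatter) from compound 1 to compound 3 and a number 5.9 percentage points lower (within the scatter) from compound 2 to compound 4, 1.6 percentage points apart, within the scatter of two such steps. These results rest on only four compounds tested at one concentration in one cell line, so they show that the two changes carry over within this small set, but not that they would do so on other cores or that the same would hold for potency.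

The compounds shown leave open what a morpholine or a plain amine would do in place of (3-chlorophenyl)amino, and whether the chloro group contributes to the step. They also leave open the effect of a longer chain in place of the ethenyl part, or of a carboxylic acid in place of the (2-aminophenyl)carbamoyl group.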